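This account rests on a few compounds, and the source may have more. Where it says the series, first, only, none or still open, it means among the compounds named here.

Measured so far in an ADME assay (liver) for metabolic stability, with Liver microsome (Homo sapiens) as the target, using microsomes and NADPH, with a stated time of 30 min, tested at 1 uM; on this read-out lower numbers stand for slow clearance and higher numbers for fast clearance:
Compound 1 `Nc1ccc(S(=O)(=O)N2CCN(c3ncc(C(O)(C(F)(F)F)C(F)(F)F)cc3Br)CC2)cn1`: < 14 mL.min-1.g-1, a limit of the assay
Compound 2 `CC(C)n1cc(-c2cc(C(O)(C(F)(F)F)C(F)(F)F)cnc2N2CCN(S(=O)(=O)c3ccc(N)nc3)CC2)cn1`: 38 mL.min-1.g-1

Among the measured compounds shown here, compound 2 holds the only true number in this assay, at 38 mL.min-1.g-1. The reading for compound 1, < 14 mL.min-1.g-1, is a limit and not a number.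

Compound 3 `Nc1ccc(S(=O)(=O)N2CCN(c3ncc(C(O)(C(F)(F)F)C(F)(F)F)cc3-c3ccccc3O)CC2)cn1` changes compound 2 in one place: 2-hydroxyphenyl in place of 1-isopropyl-1H-pyrazol-4-yl on an aromatic carbon. Here 2-hydroxyphenyl stands in place of 1-isopropyl-1H-pyrazol-4-yl on an aromatic carbon. For the measured compounds named here, one measured step bears on this place, an at least 2.7-fold higher number from compound 1 to compound 2 (0.43 log units; beyond the scatter), where 1-isopropyl-1H-pyrazol-4-yl came in place of bromo. Going by the values given here, no measured step introduces 2-hydroxyphenyl, so this guide is only partial. In this assay a change within the scatter is expected, leaning if anything towards lower numbers. The expected step is a 1.4-fold lower number from compound 2 to compound 3 (0.13 log units; within the scatter). For compound 3 the estimated value is 28 mL.min-1.g-1, with an expected range of 14 mL.min-1.g-1 to 60 mL.min-1.g-1.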

Compound 3, intrinsic clearance in microsomes: 22 mL.min-1.g-1
The estimate for compound 3 lay 1.3-fold (0.10 log units) above the measured number; measured number inside the range.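

In this assay, the step to the 2-hydroxyphenyl group is a 1.7-fold lower number from compound 2 to compound 3 (0.24 log units; within the scatter), so at this position a six-membered aromatic ring of carbon only cannot be told apart from the 1-isopropyl-1H-pyrazol-4-yl group on this read-out. Measured against bromo, the new group gives an at least 1.5-fold higher number from compound 1 to compound 3 (0.19 log units; that floor lies within the scatter), and unlike an at least 2.7-fold higher number from compound 1 to compound 2 (0.43 log units; beyond the scatter), this floor does not establish a difference beyond the scatter. The value of compound 1 is a limit of the assay and not a number: the limit of < 14 mL.min-1.g-1 in this assay, at which 1 of the 3 values shown sits.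

The compounds shown leave open what the hydroxyl group contributes, as a plain phenyl ring is not among them. They also leave open how an amine, a carboxylic acid or a short alkyl chain would read at this position.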